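A few compounds are considered here, and "the series" means these few. Any claim that something is new, unique, unknown or untested is made for them only; others in the source may bear on it.

Measured so far:
Compound 1 `COc1cccc(OC)c1C(=O)Nc1c[nH]nc1C(=O)NC1CC1` gives > 50000 nM in an ADME assay on MRC5 cells (Homo sapiens) for inhibition, with a stated time of 72 h (on this read-out lower numbers stand for an effect already at smaller amounts and higher numbers for an effect only at larger amounts of compound), which is a limit of the assay, not a number.
Compound 2 `COc1cccc(OC)c1C(=O)Nc1c[nH]nc1C(=O)NC1CCN(C(=O)OC(C)(C)C)CC1` gives > 50000 nM in this assay, likewise only a limit.
Compound 3 `COc1ccccc1C(=O)Nc1c[nH]nc1C(=O)N[C@H]1CC[C@H](OC)CC1` gives 1500 nM in this assay.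

Compound 1 thus sits at the limit of > 50000 nM in this assay, at which 2 of the 3 values shown sit, with no number of its own. Compound 4 `COc1cccc(OC)c1C(=O)Nc1c[nH]nc1C(=O)Nc1ccccn1` carries pyridin-2-yl in place of cyclopropyl on an amide-type nitrogen. No step between two measured compounds in this assay involves this change, so the size of the step from compound 1 to compound 4 cannot be read from the numbers shown. Given that compound 1 stands at the limit, the expectation is that compound 4 also returns a limit or a value close to it, with an at least 1.1-fold lower number from compound 1 to compound 4 (0.04 log units; that floor lies within the scatter) amounting to little beyond the scatter. Compound 4 is estimated at 45000 nM, within 8000 nM to 100000 nM.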

Compound 4, half-maximal effective concentration: > 50000 nM
Compound 4 was reported as a limit; the forecaster's own chance of this, stated with the estimate: 60%; middle value at least 1.1-fold (0.04 log units) away from the limit.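

Compound 1 and compound 4 both return only a limit, so the step from cyclopropyl to pyridin-2-yl cannot be read: the limit of > 50000 nM in this assay, at which 3 of the 4 values shown sit. The compounds shown leave open how far either compound lies past that limit.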